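The source may hold more compounds than are shown below. What is called first, only, known or untested is meant among the compounds shown, and "the series" means these compounds.

Of the compounds shown here, two have so far been measured in an assay on isolated protein for inhibition of advanced glycosylation end product-specific receptor (Homo sapiens), read by FRET, with stated times of 30 min and 1 h, tested at 4 uM; on this read-out lower numbers stand for less inhibition and higher numbers for more inhibition at the one concentration tested (going by the name of the read-out). Going by the values given here, compound 1 `CC(C)N1CCC(Oc2ccc(-c3nc4ccc(Oc5ccc(Cl)cc5)cc4o3)cc2)CC1` is the only one with a number: in this assay compound 1 gives 12.7%, a small effect at the single concentration tested. Compound 2 `CCN(CC)CCCOc1ccc(-c2nc3ccc(Oc4ccc(C(C)(C)C)cc4)cc3o2)cc1` was reported as "not active" (no number reported) in this assay, so no figure stands for it; it can only be placed at the weak end of the read-out, with nothing to set beside the value of compound 1.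

Compound 3 `CC(C)(C)c1ccc(Oc2ccc3nc(-c4ccc(OCCCN5CCCC5)cc4)oc3c2)cc1` differs from compound 2 in one place: pyrrolidin-1-yl in place of diethylamino on a saturated chain carbon, three bonds along the chain from an oxygen on an aromatic ring. Among the compounds with values here, no measured pair shows this change, so its size in this assay is unknown. Within the data shown here, compound 2 was reported as "not active" (no number reported), and nothing among the measured compounds suggests that this change would lift inhibition; a step beyond the scatter in either direction is therefore not expected, and the likeliest outcome is that compound 3 also sits near the bottom of the read-out, where a report of "not active" rather than a number remains quite possible. Compound 3 is expected to give about 5%, within a range from 0% to 15%.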

Compound 3, a percentage reported as inhibition, at one concentration (the size of the read-out at that concentration, not a potency): "not active" (no number reported)
Compound 3 has no reported number here; the estimate stays without a comparison.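

In this assay compound 2 and compound 3 were both reported as "not active", without a number, so no step can be read for the change from diethylamino to pyrrolidin-1-yl. No evidence is available that bears on this result. The compounds shown leave open whether this change alters inhibition at all.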